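Swapping bromo for fluoro on the benzyl of compound 3

This account rests on a few compounds, and the source may have more. Where it says the series, first, only, none or still open, it means among the compounds named here.

Three chalcone-type compounds have been measured in a functional assay on MCF7 cells (Homo sapiens) for inhibition, read by MTT assay, with a stated time of 48 h, tested at 10 uM; on this read-out lower numbers stand for less inhibition of growth and higher numbers for more inhibition of growth at the one concentration tested. Compound 1 `C#CCOc1ccc(/C=C/C(=O)c2ccc([N+](=O)[O-])cc2)cc1` gives 44%. Compound 2 `O=C(/C=C/c1ccc(OCc2cn(Cc3cccc(Br)c3)nn2)cc1)c1ccc(Br)cc1` gives 36%, and compound 3 `O=C(/C=C/c1ccc(OCc2cn(Cc3ccc(Br)cc3)nn2)cc1)c1ccc(Br)cc1` gives 23%, the lowest of the three numbers: compound 2 lies nearest, and compound 1 furthest above it. Going by the values given here, the only one-place step among them, a number 13 percentage points lower from compound 2 to compound 3 (beyond the scatter), is a change of position of the bromine on the benzyl group, not of the halogen itself.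

Compound 4 `O=C(/C=C/c1ccc(OCc2cn(Cc3ccc(F)cc3)nn2)cc1)c1ccc(Br)cc1` is not yet measured. It differs from compound 3 in one place: fluoro in place of bromo on an aromatic carbon. No measured step covers an exchange of one halogen for another, so nothing in the numbers shown speaks for a shift in either direction. On that basis the step from compound 3 to compound 4 in this assay is expected to stay within the usual scatter, a number 2 percentage points higher from compound 3 to compound 4 (within the scatter). Compound 4 is therefore estimated at 25%, in a range from 10% to 42%.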

Compound 4, percent growth inhibition at one concentration: 37%
Estimate against measurement, compound 4: 12 percentage points below; the range from low to high includes it.
By their numbers in this assay, from the lowest: compound 3; then compounds 2, 4 and 1 (each within the scatter of the next).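

In this assay the identity of the halogen on the benzyl group matters, not only its position: fluoro in place of bromo, on an aromatic carbon para to a large group, gives a number 14 percentage points higher from compound 3 to compound 4 (beyond the scatter). With 4-fluorophenyl in place of 3-bromophenyl the change is a number 1 percentage points higher from compound 2 to compound 4 (within the scatter), so among these three benzyl variants the lower number belongs to the 4-bromobenzyl group of compound 3 alone. Nothing measured here accounts for this difference between the two halogens.

The compounds shown leave open whether chloro, methoxy or an amine at this place would give a number nearer that of compound 3 or that of compound 4. They also leave open whether 3-fluorophenyl would differ from 4-fluorophenyl as 3-bromophenyl differs from 4-bromophenyl.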